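A few compounds are considered here, and "the series" means these few. Any claim that something is new, unique, unknown or untested is made for them only; others in the source may bear on it.

Values in an ADME assay on HCT-116 cells (Homo sapiens) for cytotoxicity, read by CellTiter-Glo, with a stated time of 72 h; a higher number here means a weaker inhibitor, a lower number a stronger inhibitor:

Compound 1 `CC1CCN(C2CCN(S(=O)(=O)c3cccnc3Cl)CC2)CC1`: > 10000 nM, a limit.
Compound 2 `CC1CCN(C2CCN(S(=O)(=O)c3ccc(Cl)nc3)CC2)CC1`: > 10000 nM, a limit.
Compound 3 `CCc1ccc(S(=O)(=O)N2CCC(N3CCC(C)CC3)CC2)cc1`: > 5000 nM, a limit.

Compound 3 is known only through a limit, > 5000 nM. None of the three compounds has an exact number, so they cannot be ranked against one another.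

Compound 4 `CC1CCN(C2CCN(S(=O)(=O)c3ccc(Cl)cc3Cl)CC2)CC1` keeps the core of compound 3 and changes only the group on the sulfonyl sulfur, where 2,4-dichlorophenyl takes the place of 4-ethylphenyl: 2,4-dichlorophenyl in place of 4-ethylphenyl on a sulfonyl sulfur.

Three measured steps change this same group: a step that the two limits leave unreadable from compound 1 to compound 3, a step that the two limits leave unreadable from compound 2 to compound 3 and a step that the two limits leave unreadable from compound 1 to compound 2. None of them has a readable size, so they give no measured sign that swapping this group moves the result in this assay. What they do show is that all three compounds ended at a limit rather than at a number. The same outcome is therefore the most likely one for the new compound, with no step beyond the usual scatter expected and no direction favoured.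

The expected change is a step that the limit leaves unreadable from compound 3 to compound 4. Compound 4 is estimated at 8000 nM, with an expected range of 3000 nM to 15000 nM.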

Compound 4, half-maximal inhibitory concentration: > 5000 nM
Compound 4 gave a limit, no number; the forecaster's own chance of this, stated with the estimate: 80%; the middle value does not contradict the limit.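

In this assay compound 4 gives > 5000 nM, which is a limit and not a number. Among the compounds shown here, compound 1, compound 2 and compound 3 are also known only through limits, so no step to compound 4 can be read. The compounds shown leave open whether changing the group on the sulfonyl sulfur moves the result at all.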